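Adding a Methoxy Group to a Weakly Cytotoxic Series

The source may report more compounds than this note shows. Statements on the series, on what has been measured and on what is new or still open speak of the compounds shown alone.

Of the compounds shown here, three sharing one core have been tested in a functional assay on Ehrlich cells (Mus musculus) for cytotoxicity, read by MTT assay, with a stated time of 48 h; a lower number here means a stronger inhibitor, a higher number a weaker inhibitor. Compound 1 `COc1ccc(-c2csc(NC(=O)COc3ccc(C(=O)c4ccccc4)cc3C)n2)cc1` gives 28400 nM, and compound 2 `COc1ccc(-c2csc(NC(=O)COc3ccc(C(=O)c4ccc(C)cc4)cc3C)n2)cc1` gives 20700 nM. Among the measured compounds shown here, the single measured step, a 1.4-fold lower number from compound 1 to compound 2 (0.14 log units; within the scatter), is within the scatter. Compound 3 `Cc1cc(C(=O)c2ccc(F)cc2)ccc1OCC(=O)Nc1nc(-c2ccccc2)cs1` gives 37400 nM, the highest of the three numbers as written, yet within the scatter of both compound 1 and compound 2. Compound 4 `COc1ccc(-c2csc(NC(=O)COc3ccc(C(=O)c4ccc(F)cc4)cc3C)n2)cc1` differs from compound 3 by methoxy in place of hydrogen on an aromatic carbon. For the measured compounds named here, no measured step covers this change; the one step that exists, a methyl added on an aromatic carbon, stays within the scatter. The expected step of a 1.2-fold lower number from compound 3 to compound 4 (0.10 log units; within the scatter) is therefore none beyond the scatter. Compound 4 is estimated at 30000 nM, with a range from 14000 nM to 65000 nM.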

Compound 4, half-maximal inhibitory concentration: 5400 nM
Compound 4: the middle estimate sits 5.6-fold (0.74 log units) above what was measured; the measured number lies below the stated range.
By their numbers in this assay, from the lowest: compound 4; then compounds 2, 1 and 3 (each within the scatter of the next).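

In this assay, phenyl to 4-methoxyphenyl gives a 6.9-fold lower number from compound 3 to compound 4 (0.84 log units; beyond the scatter), so a change at this position now has a measured step beyond the scatter. With the methoxy in place, fluoro in place of hydrogen gives a 5.3-fold lower number from compound 1 to compound 4 (0.72 log units; beyond the scatter) and fluoro in place of methyl gives a 3.8-fold lower number from compound 2 to compound 4 (0.58 log units; beyond the scatter), although methyl in place of hydrogen stayed within the scatter. No measurement shown accounts for these differences.

Going by these compounds, whether methoxy gives a similar step without the fluoro remains open. So does whether a hydroxyl or an amine at this position would match methoxy.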